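Hydroxy for Chloro on the Aryl Ring of Compound 3

The compounds below may be only part of what the source reports. "The series", "measured", "known", "first", "only" and "open" are said of these compounds alone.

Compound 3 `O=C1CSC(c2cccc(Cl)c2)N1CCN1CCCCC1` was tested in an ADME assay on Vero cells (Chlorocebus sabaeus) for cytotoxicity, read by neutral red uptake, tested at 394 ug/mL (on this read-out higher numbers stand for a weaker effect at the one concentration tested and lower numbers for a stronger effect), where compound 3 gives 45%. Among the three measured compounds, compound 3 stands second highest: compound 1 `O=C1CSC(c2c(Cl)cccc2Cl)N1CCN1CCCCC1` gives 32%, lower by a margin beyond the scatter, while compound 2 `COc1ccc(C2SCC(=O)N2CCN2CCCCC2)cc1` gives 73%, higher by a margin also beyond the scatter. Compound 4 `O=C1CSC(c2cccc(O)c2)N1CCN1CCCCC1` has not yet been measured. It differs from compound 3 in one place: hydroxy in place of chloro on an aromatic carbon. Within the data shown here, no measured pair in this set carries the same change, so any expectation rests on the three numbers alone. A modest upward step a number 15 percentage points higher from compound 3 to compound 4 (beyond the scatter) is expected, toward a weaker effect. Compound 4 is accordingly estimated at 60%, within a range from 40% to 80%.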

Compound 4, a percentage reported as activity, at one concentration (the size of the read-out at that concentration, not a potency): 100%
The estimate for compound 4 lay 40 percentage points below the measured number, and the stated range ends below it.
By their numbers in this assay, from the lowest: compound 1; then compound 3; then compound 2; then compound 4.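

In this assay, hydroxy in place of chloro on this aromatic carbon gives a large step, a number 55 percentage points higher from compound 3 to compound 4 (beyond the scatter), toward a weaker effect at the one concentration tested. As the only single-place step shown, it establishes that the read-out at this position responds strongly to the change from 3-chlorophenyl to 3-hydroxyphenyl. Nothing measured here accounts for the size of this step.

From the compounds shown here alone, whether an amine or a carboxylic acid at this place would read like hydroxy or like chloro remains open. So does whether hydroxy elsewhere on the ring would give a step of similar size.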